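Swapping nitrooxy for methyl on a benzanilide-type series

The source may hold more compounds than are shown below. What is called first, only, known or untested is meant among the compounds shown, and "the series" means these compounds.

Values in a functional assay on SK-BR-3 cells (Homo sapiens) for antiproliferative activity, read by CCK-8 assay and cell counting, with a stated time of 72 h; on this read-out higher numbers stand for weaker inhibition and lower numbers for stronger inhibition:
Compound 1 `O=C(Nc1ccccc1)c1ccc(CCl)cc1`: 700 nM
Compound 2 `O=C(Nc1ccccc1)c1ccc(CO[N+](=O)[O-])cc1`: 700 nM

Compound 2 stands level with compound 1 in this assay, and compound 2 reads 700 nM. The next compound to be tested is compound 3 `CCc1ccc(C(=O)Nc2ccccc2)cc1`, which has methyl in place of nitrooxy on a saturated chain carbon bound to an aromatic carbon, so that (nitrooxy)methyl becomes ethyl: methyl in place of nitrooxy on a saturated chain carbon bound to an aromatic carbon.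

Among the compounds with values here, only one measured step bears on this change. It acts at the same place, with nitrooxy in place of chloro, and it showed no change at the digits printed from compound 1 to compound 2 (within the scatter). Within the data shown here, that step says little about the present change, since no measured compound carries ethyl and both measured groups leave in neither case a bare chain end. On the evidence of no change at the digits printed from compound 1 to compound 2 (within the scatter), no step beyond the scatter is expected in this assay, although a move towards weaker inhibition cannot be excluded. The estimated size of the change is a 1.4-fold higher number from compound 2 to compound 3 (0.15 log units; within the scatter). For compound 3 the expected value is 1000 nM. The estimated range for compound 3 runs from 300 nM to 4000 nM.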

Compound 3, half-maximal inhibitory concentration: > 100000 nM
Compound 3: a limit, no number (the forecaster's own chance of this, stated with the estimate: 10%); middle value at least 100-fold (2.00 log units) from the limit.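

In this assay, the place on a saturated chain carbon bound to an aromatic carbon proves far from indifferent to what it carries: the earlier pair gave no change at the digits printed from compound 1 to compound 2 (within the scatter), whereas methyl in place of nitrooxy gives an at least 140-fold higher number from compound 2 to compound 3 (2.15 log units; beyond the scatter), and methyl in place of chloro gives an at least 140-fold higher number from compound 1 to compound 3 (2.15 log units; beyond the scatter). The reading for compound 3 is a limit of the assay and not a number: the limit of > 100000 nM in this assay, at which 1 of the 3 values shown sits. Among these three compounds, the shared core with ethyl does not reach the inhibition seen in compound 1 and compound 2, so the activity depends on the group at this place and not on the core alone.

As far as these compounds go, the true size of both new steps stays open, as does the question of whether chloro and nitrooxy share something specific or whether methyl alone is the exception. A hydroxyl, an amine or a fluoro at this place would separate those readings, and a longer chain carrying chloro or nitrooxy would show how much the distance from the aromatic carbon counts.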